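The compounds below may be only part of what the source reports. "The series", "measured", "known", "first", "only" and "open" are said of these compounds alone.

In a functional assay on A2780 cells (Homo sapiens) for antiproliferative activity, read by fluorescence, with a stated time of 72 h (on this read-out higher numbers stand for weaker inhibition and lower numbers for stronger inhibition), compound 1 `CC(=O)N1CCC(C(=O)N2Cc3c(NC(=O)c4ccc(F)cc4)n[nH]c3C2(C)C)CC1` gives > 10000 nM, which is a limit of the assay and not a number. So compound 1 has no exact value to start from. Among the measured compounds shown here, the only true reading so far belongs to another compound: compound 2 `CN1CCC(C(=O)Nc2n[nH]c3c2CN(C(=O)C(C)(C)C)C3(C)C)CC1` gives 350 nM. For the measured compounds named here, no measured step in a single place connects it to compound 1, so it serves only as a loose reference.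

The next compound, compound 3 `CCN1CCC(C(=O)N2Cc3c(NC(=O)c4ccc(F)cc4)n[nH]c3C2(C)C)CC1`, keeps the core of compound 1 and changes one group. It has ethyl in place of acetyl on an amine nitrogen in a ring, a swap from 1-acetylpiperidin-4-yl to 1-ethylpiperidin-4-yl, counted as ethyl in place of acetyl on an amine nitrogen in a ring. Going by the values given here, no measured step shows what this swap does, so any forecast is uncertain. A moderate move towards stronger inhibition in this assay seems the likeliest outcome, though a result again at the limit would be no surprise. The expected change is an at least 3.3-fold lower number from compound 1 to compound 3 (0.52 log units; beyond the scatter). Compound 3 is expected to read about 3000 nM, with an estimated range from 600 nM to 10000 nM.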

Compound 3, half-maximal inhibitory concentration: 290 nM
The estimate for compound 3 lay 10-fold (1.01 log units) above the measured number; measured number outside the range, below it.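

At this position, on an amine nitrogen in a ring, the choice of group has a strong influence in this assay: ethyl in place of acetyl gives an at least 34-fold lower number from compound 1 to compound 3 (1.53 log units; beyond the scatter), a large step. Until now the shared core with the 4-fluorobenzoyl amide had no exact reading, and this result shows that it can carry real inhibition, since compound 3 gives 290 nM with the 1-ethylpiperidin-4-yl group. The reading for compound 1 is a limit of the assay and not a number, so the step fixes only a lower bound on the size of the change: the limit of > 10000 nM in this assay, at which 1 of the 3 values shown sits.

With a single swap at this nitrogen, the compounds shown cannot separate what ethyl itself contributes from what follows from removing the acetyl group and its carbonyl. Methyl, a longer chain such as propyl, or a bare ring amine with only a hydrogen on this nitrogen would show whether the number moves with the chain or stays much the same once the acetyl group is gone.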